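Replacing 3,5-difluorophenyl with 4-nitrophenyl on an amide-type nitrogen

A few compounds are considered here, and "the series" means these few. Any claim that something is new, unique, unknown or untested is made for them only; others in the source may bear on it.

Measured in a functional assay on RT-112 cells (Homo sapiens) for antiproliferative activity, read by MTT assay, with a stated time of 72 h (a lower number here means a stronger inhibitor of growth, a higher number a weaker inhibitor of growth), so far:
Compound 1 `COc1cc(Nc2ncnc3c(NC(=O)Nc4ccc(C)c(C)c4)cccc23)cc(OC)c1` gives 8.8 nM
Compound 2 `COc1cc(Nc2ncnc3c(NC(=O)Nc4cc(Cl)cc(Cl)c4)cccc23)cc(OC)c1` gives 30.2 nM
Compound 3 `COc1cc(Nc2ncnc3c(NC(=O)Nc4cc(F)cc(F)c4)cccc23)cc(OC)c1` gives 2630 nM

Compound 3 has the highest number of the three and is the weakest inhibitor of growth among them. The gaps to the others are large, with an 87-fold higher number from compound 2 to compound 3 (1.94 log units; beyond the scatter) and a 300-fold higher number from compound 1 to compound 3 (2.48 log units; beyond the scatter). Compound 4 `COc1cc(Nc2ncnc3c(NC(=O)Nc4ccc([N+](=O)[O-])cc4)cccc23)cc(OC)c1` keeps the shared core and has 4-nitrophenyl in place of 3,5-difluorophenyl on an amide-type nitrogen.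

All three measured steps change the group at this same place. Besides the two large steps there is a modest one, a 3.4-fold higher number from compound 1 to compound 2 (0.54 log units; beyond the scatter). Within the data shown here, no measured compound carries a nitro group, so the guide is weak. Still, compound 3 at 2630 nM sits well above both other compounds, so a replacement at this place is expected to give a lower number in this assay, by a moderate to large step. The expected step is an 8.8-fold lower number from compound 3 to compound 4 (0.94 log units; beyond the scatter). For compound 4 the estimated value is 300 nM, with an expected range of 40 nM to 2500 nM.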

Compound 4, concentration for 50% growth inhibition: > 20000 nM
Compound 4: no number, only a limit (the forecaster's own chance of this, stated with the estimate: 5%); middle value at least 66-fold (1.82 log units) away from the limit.
By their numbers in this assay, from the lowest: compound 1; then compound 2; then compound 3. At a limit, above all of these: compound 4.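

In this assay the result for compound 4 is a limit and not a number: the limit of > 20000 nM in this assay, at which 1 of the 4 values shown sits.

Even so, the steps to it are all beyond the scatter: an at least 7.6-fold higher number from compound 3 to compound 4 (0.88 log units; beyond the scatter), an at least 660-fold higher number from compound 2 to compound 4 (2.82 log units; beyond the scatter) and an at least 2200-fold higher number from compound 1 to compound 4 (3.35 log units; beyond the scatter). Compound 3 therefore no longer marks the weak end at this amide-type nitrogen, and changing this one group alone now takes the shared core from the low number of compound 1 to the limit of the assay.

Among these compounds, how far the true value of compound 4 lies past its limit stays open, and the single nitro compound cannot show whether the nitro group itself or its ring placement matters more. Also open, as far as these compounds go, is how a 4-aminophenyl or 4-carboxyphenyl group would behave on the same nitrogen.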